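Swapping a Phenyl for Chloro on a Pyridine Agonist

A few compounds are considered here, and "the series" means these few. Any claim that something is new, unique, unknown or untested is made for them only; others in the source may bear on it.

Measured so far:
- compound 1, `O=C(O)CCc1ccc(C#Cc2ccnc(-c3ccccc3)c2)cc1`: 97%
- compound 2, `O=C(O)CCc1ccc(C#Cc2cccs2)cc1`: 97%

Both measured compounds share a propanoic acid chain on a benzene ring joined through an alkyne to a second aromatic ring, and both were tested in an in vitro functional assay on 1321-N1 cells for agonist activity at Free fatty acid receptor 1 (Homo sapiens), read by fluorescence, spectrophotometry and calcium flux; on this read-out lower numbers stand for smaller maximal responses and higher numbers for larger maximal responses. In this assay compound 1 gives 97%, and compound 2 gives 97%. The two values sit level with each other within the scatter of the method, so neither can be called the larger responder; both reach essentially the full response of the reference.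

Compound 3, `O=C(O)CCc1ccc(C#Cc2ccnc(Cl)c2)cc1`, has not yet been measured. It differs from compound 1 in one place: chloro in place of phenyl on an aromatic carbon. A large aromatic substituent is thus replaced by a single halogen atom at the same position of the shared core.

Going by the values given here, no measured pair shows what such a change does to the maximal response here. Because compound 1 sits at 97% and compound 2, with a quite different second ring, also sits at 97%, the maximal response seems tolerant of variation in this part of the molecule. The step of a number 9 percentage points lower from compound 1 to compound 3 (within the scatter) is therefore expected to be small, at most a mild decrease. Compound 3 is estimated to give 88%, with a plausible range from 60% to 105%.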

Compound 3, largest response reached (reported as efficacy), in percent of the reference or control that the assay uses: 94%
Estimate against measurement, compound 3: 6 percentage points below; the range from low to high includes it.
By their numbers in this assay, from the lowest: compounds 3, 1 and 2 (each within the scatter of the next).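

Putting chloro in place of phenyl on an aromatic carbon, next to the ring nitrogen, gives in this assay a number 3 percentage points lower from compound 1 to compound 3 (within the scatter) and so no change that can be told from the scatter. Going by these compounds alone, this is the first direct view of this position: one chlorine atom stands where a six-carbon aromatic ring stood, and the maximal response of compound 3 remains level with that of compound 1, so a ring at this place is not required to reach such a response in this read-out. What lies behind this tolerance remains unexplained, with nothing at hand that bears on it.

The compounds shown leave open whether the response would also hold with an amine, a methoxy group or a plain hydrogen at this same place. A maximal response also tells only how far the response goes, so whether chloro and phenyl differ in the concentration needed to reach it stays an open question.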